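Aryl swap at the hydrazone carbon in a small series

A few compounds are considered here, and "the series" means these few. Any claim that something is new, unique, unknown or untested is made for them only; others in the source may bear on it.

Compound 3 `COc1cc(/C=N/NC(=O)Nc2ccc(Oc3ccnc(-c4nncn4CCN(C)C)c3)c(F)c2)cc(OC)c1OC` gives, in a functional assay on NCI-H460 cells (Homo sapiens) for cytotoxicity, read by MTT assay, with a stated time of 72 h (a higher number here means a weaker inhibitor, a lower number a stronger inhibitor), 2770 nM. Compound 1 `COc1ccc(OC)c(/C=N/NC(=O)Nc2ccc(Oc3ccnc(-c4nncn4CCN(C)C)c3)c(F)c2)c1` gives 2930 nM and compound 2 `COc1ccc(/C=N/NC(=O)Nc2ccc(Oc3ccnc(-c4nncn4CCN(C)C)c3)c(F)c2)c(OC)c1OC` gives 1790 nM. On these numbers compound 3 sits second highest, nearest to compound 1 and furthest from compound 2, with every gap within the scatter. All steps among the measured compounds alter the aryl group on the carbon with a double bond to nitrogen: a 1.1-fold lower number from compound 1 to compound 3 (0.02 log units; within the scatter), a 1.5-fold higher number from compound 2 to compound 3 (0.19 log units; within the scatter) and a 1.6-fold lower number from compound 1 to compound 2 (0.21 log units; within the scatter).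

Compound 4 `CN(C)CCn1cnnc1-c1cc(Oc2ccc(NC(=O)N/N=C/c3cccc(Cl)c3Cl)cc2F)ccn1` is not yet measured. It differs from compound 3 by 2,3-dichlorophenyl in place of 3,4,5-trimethoxyphenyl on a carbon with a double bond to nitrogen. The measured steps bear on this change only in that they exchange the same aryl group; none of them trades an oxygen-bearing ring for a chlorine-bearing one, so the support is indirect. For the measured compounds named here, since every exchange at this position so far stayed within the scatter, no step beyond the scatter is expected in this assay, but the range is widened for the larger structural change. The estimated step of a 1.1-fold lower number from compound 3 to compound 4 (0.04 log units; within the scatter) is accordingly small. For compound 4 the expected value in this assay is 2500 nM, within a range from 900 nM to 7000 nM.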

Compound 4, half-maximal inhibitory concentration: 72 nM
Beside the measured number, compound 4's estimate is 35-fold (1.54 log units) above it; measured number below the stated range.
By their numbers in this assay, from the lowest: compound 4; then compounds 2, 3 and 1 (each within the scatter of the next).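

The aryl group on the carbon with a double bond to nitrogen is far from silent in this assay: 2,3-dichlorophenyl brings a 38-fold lower number from compound 3 to compound 4 (1.59 log units; beyond the scatter) and a 25-fold lower number from compound 2 to compound 4 (1.40 log units; beyond the scatter) and also a 41-fold lower number from compound 1 to compound 4 (1.61 log units; beyond the scatter) while the exchanges among the methoxy-bearing aryl groups of compound 1, compound 2 and compound 3 all stayed within the scatter. For the compounds shown here, compound 4 therefore stands as the strongest inhibitor of the four, and the flat picture from the earlier compounds holds only among those methoxy-bearing groups. Nothing available accounts for this gain, and the data cannot separate the loss of the methoxy groups from the arrival of the chlorines.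

Going by these compounds, whether the gain depends on chlorine at all remains open: an unsubstituted phenyl, a monochlorophenyl or a trifluoromethylphenyl on the same carbon would help to separate these two parts of the change. Also open, on these data alone, is whether the gain carries over when the dimethylaminoethyl chain on the shared core gives way to a morpholine or a carboxylic acid.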